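Nitrophenyl replaces methoxyphenyl on the benzylic ether side chain

The source may report more compounds than this note shows. Statements on the series, on what has been measured and on what is new or still open speak of the compounds shown alone.

Of the compounds shown here, three sharing one core have been measured in a functional assay on CHO-K1 cells for antagonist activity at prostaglandin E2 receptor EP1 subtype (Homo sapiens), read by FLIPR; a lower number here means a stronger inhibitor, a higher number a weaker inhibitor. Compound 1 `Cc1cc(C(=O)O)nn1Cc1cc(Br)ccc1OCc1ccc(Cl)cc1Cl` gives 0.49 nM, compound 2 `Cc1cc(C(=O)O)nn1Cc1cc(Br)ccc1OCc1ccc(F)cc1` gives 11.8 nM, and compound 3 `COc1ccccc1COc1ccc(Br)cc1Cn1nc(C(=O)O)cc1C` gives 69.2 nM. Compound 3 therefore stands weakest of the three: the step of a 5.9-fold higher number from compound 2 to compound 3 (0.77 log units; beyond the scatter) and the step of a 140-fold higher number from compound 1 to compound 3 (2.15 log units; beyond the scatter) are both beyond the scatter, and the remaining step of a 24-fold higher number from compound 1 to compound 2 (1.38 log units; beyond the scatter) shows how much the group on the saturated chain carbon bound to an oxygen on the aromatic ring can move the number.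

Compound 4 `Cc1cc(C(=O)O)nn1Cc1cc(Br)ccc1OCc1cccc([N+](=O)[O-])c1` carries the same core with the change (3-nitrophenyl in place of 2-methoxyphenyl on a saturated chain carbon bound to an oxygen on an aromatic ring). Among the compounds with values here, every measured step bears on this position, and each was modest to large, so a step beyond the scatter is plausible in either direction; with no nitro-bearing analogue measured, the direction rests only on the spread seen so far. The estimate is a step of a 2.3-fold lower number from compound 3 to compound 4 (0.36 log units; beyond the scatter) in this assay, expected to improve somewhat on compound 3. For compound 4 the expected value in this assay is 30 nM, within a range from 5 nM to 200 nM.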

Compound 4, inhibition constant: 339 nM
For compound 4 the middle estimate is 11-fold (1.05 log units) below the measured one, outside the stated range (above it).
By their numbers in this assay, from the lowest: compound 1; then compound 2; then compound 3; then compound 4.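

In this assay, the 3-nitrophenyl group extends the upper end of the range at this position: the step is a 4.9-fold higher number from compound 3 to compound 4 (0.69 log units; beyond the scatter), which makes compound 4 the weakest of the four. Within the data shown here, the gap to the best groups also widens, with a 29-fold higher number from compound 2 to compound 4 (1.46 log units; beyond the scatter) and a 690-fold higher number from compound 1 to compound 4 (2.84 log units; beyond the scatter), so the group on the saturated chain carbon bound to an oxygen on an aromatic ring can cost far more than the earlier compounds showed. Nothing given here accounts for the position of the nitro-bearing ring in this order.

The compounds shown leave open whether an amine or a nitrile in place of the nitro group on the same ring would bring the number back toward that of compound 2. They also leave open whether a single chlorine on the ring would retain the strength of compound 1.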